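The source may hold more compounds than are shown below. What is called first, only, known or untested is meant among the compounds shown, and "the series" means these compounds.

Compound 1 `CCOC(=O)c1c(N)sc(/N=C/c2ccccc2)c1C(=O)OCC` is one of three close analogues sharing a core that differ only in the aryl group on the carbon with a double bond to nitrogen. In a functional assay on HeLa cells (Homo sapiens) for inhibition, read by MTT assay, with a stated time of 48 h (a lower number here means a stronger inhibitor, a higher number a weaker inhibitor), compound 1 gives 31200 nM. Compound 2 `CCOC(=O)c1c(N)sc(/N=C/c2ccncc2)c1C(=O)OCC` gives 35400 nM in this assay, and compound 3 `CCOC(=O)c1c(N)sc(/N=C/c2ccc(C)cc2)c1C(=O)OCC` gives 41900 nM. The step of a 1.1-fold higher number from compound 1 to compound 2 (0.05 log units; within the scatter) and the step of a 1.3-fold higher number from compound 1 to compound 3 (0.13 log units; within the scatter) are both within the scatter, as is the step of a 1.2-fold higher number from compound 2 to compound 3 (0.07 log units; within the scatter), so compound 1 cannot be separated from the other two on these numbers.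

Compound 4 `CCOC(=O)c1c(N)sc(/N=C/c2ccc([N+](=O)[O-])o2)c1C(=O)OCC` is not yet measured. It differs from compound 1 as follows: 5-nitrofuran-2-yl in place of phenyl on a carbon with a double bond to nitrogen. Among the measured compounds shown here, the only steps that bear on this change are the two aryl replacements on the same carbon, from compound 1 to compound 2 and from compound 1 to compound 3, and neither moved the number beyond the scatter. On that basis no step beyond the scatter is expected in this assay for compound 4, with the estimate for a 1.2-fold lower number from compound 1 to compound 4 (0.06 log units; within the scatter) sitting close to no change. Compound 4 is therefore expected to give about 27000 nM, with a range from 7000 nM to 90000 nM.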

Compound 4, half-maximal inhibitory concentration: 4700 nM
Estimate against measurement, compound 4: 5.7-fold (0.76 log units) above, outside the stated range (below it).
By their numbers in this assay, from the lowest: compound 4; then compounds 1, 2 and 3 (each within the scatter of the next).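

In this assay the carbon with a double bond to nitrogen proves sensitive to the group it carries, for 5-nitrofuran-2-yl gives a 6.6-fold lower number from compound 1 to compound 4 (0.82 log units; beyond the scatter) and a 7.5-fold lower number from compound 2 to compound 4 (0.88 log units; beyond the scatter) and also an 8.9-fold lower number from compound 3 to compound 4 (0.95 log units; beyond the scatter) while phenyl, pyridin-4-yl and 4-methylphenyl could not be told apart. The entering group brings a five-membered aromatic ring with 1 hetero atom and a nitro group in a single change, so these compounds cannot apportion the lower number between the two. Nothing available explains the lower number.

From the compounds shown here alone, it remains open whether furan-2-yl without the nitro group or 4-nitrophenyl would keep the lower number. Going by these compounds, it is also open whether an amine or a carboxylic acid in place of the nitro group on the furan ring would do so.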